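This account rests on a few compounds, and the source may have more. Where it says the series, first, only, none or still open, it means among the compounds named here.

Working notes on the series. The shared core of compound 1 `Cc1cc(C(=O)NCc2ccccc2)nn1Cc1cc(Cl)ccc1OCc1ccccc1` is kept in compound 2 `Cc1cc(NC(=O)C2CCCO2)nn1Cc1cc(Cl)ccc1OCc1ccccc1` and compound 3 `Cc1cc(NC(=O)c2c(F)cccc2F)nn1Cc1cc(Cl)ccc1OCc1ccccc1`. In a physicochemical assay for lipophilicity, at pH 7.4 (a higher number here means a more lipophilic compound, a lower number a more polar compound), compound 1 gives > 3.7, which is a limit of the assay and not a number. In this assay compound 2 likewise gives > 3.7, again a limit rather than a number. Among the measured compounds shown here, the one step that joins two measured compounds, a step that the two limits leave unreadable from compound 1 to compound 2, is therefore unreadable in size and direction; the only evidence is the limit of > 3.7 in this assay, at which 2 of the 2 values shown sit, which says where both measured values sit and nothing more.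

Compound 3 differs from compound 2 in one place: 2,6-difluorophenyl in place of oxolan-2-yl on a carbonyl carbon. Cut one bond further out, the same difference reads as (oxolan-2-yl)carbonyl to (2,6-difluorophenyl)carbonyl.

For the measured compounds named here, no measured step bears readably on this change, so the expectation rests on the position of compound 2 at the limit together with the change itself. Compound 3 is expected to remain at or beyond that limit, with the step from compound 2 to compound 3 estimated as a step that the limit leaves unreadable from compound 2 to compound 3. The estimate for compound 3 in this assay is 4.6, within a range from 3.9 to 5.3, with the assay most likely again reporting only a limit.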

Compound 3, distribution coefficient: > 3.7
Compound 3 gave a limit, no number (the forecaster's own chance of this, stated with the estimate: 85%); the middle value lies beyond the limit too.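

In this assay compound 3 gives > 3.7 which is a limit of the assay and not a number. The steps joining compound 3 to compound 1 and compound 2 therefore cannot be read in size or direction: the limit of > 3.7 in this assay, at which 3 of the 3 values shown sit. The compounds shown leave open how far apart compound 1, compound 2 and compound 3 lie in this assay and whether the changes between them shift the read-out at all.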